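The compounds below may be only part of what the source reports. "The series", "measured", "known", "first", "only" and "open" are said of these compounds alone.

Of the compounds shown here, two have been read in a toxicity assay on MRC5 cells (Homo sapiens) for inhibition, read by MTT assay, with a stated time of 72 h (a higher number here means a weaker inhibitor, a lower number a stronger inhibitor), and neither gives a number. Compound 1 `CCCCCCCCCCCCSCCc1ccc(OCc2ccc(OC)cc2)c(OCc2ccc(OC)cc2)c1` reads > 50000 nM, which is a limit of the assay. Compound 2 `CCCCCCCCCCCCCCCC(=O)OCCc1ccc(O)c(O)c1` reads > 50000 nM, which is also a limit of the assay. Going by the values given here, compound 2 therefore stands at the limit of > 50000 nM in this assay, at which 2 of the 2 values shown sit, and the series offers no measured step from which to size a change.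

The next compound is compound 3 `CCCCCCCCCC(=O)OCCc1ccc(O)c(O)c1`, which differs from compound 2 at one place in the chain: hydrogen in place of hexyl on a saturated chain carbon, nine bonds along the chain from a carbonyl carbon. This is hydrogen in place of hexyl on a saturated chain carbon, nine bonds along the chain from a carbonyl carbon. Cut one bond further out, the same difference reads heptyl to methyl.

In this assay no change beyond the usual scatter is expected, in either direction, though this expectation rests only on two limit readings. The estimated a number no higher from compound 2 to compound 3 (the limit leaves the size open) is expected to be small, and another limit reading is the likeliest report. For compound 3 the estimated value is 50000 nM, with an expected range of 20000 nM to 100000 nM.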

Compound 3, half-maximal inhibitory concentration: 71100 nM
For compound 3 the middle estimate is 1.4-fold (0.15 log units) below the measured one; the measured number falls inside the stated range.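

No step can be read from compound 2 to compound 3 in this assay, as compound 2 gives only a limit: the limit of > 50000 nM in this assay, at which 2 of the 3 values shown sit.

The compounds shown leave open whether hydrogen in place of hexyl on this saturated chain carbon changes the reading in this assay at all, in either direction.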